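The compounds below may be only part of what the source reports. "The series", "measured", "known", "first", "only" and "open" are said of these compounds alone.

Three measured compounds share one core and differ only in a substituted aromatic ring carried on an amine nitrogen: compound 1 `Nc1nc(N)c(CCCN(Cc2ccc(NC(CCC(=O)O)C(=O)O)cc2)c2cc(F)c([N+](=O)[O-])cc2[N+](=O)[O-])c(O)n1`, compound 2 `Nc1nc(N)c(CCCN(Cc2ccc(NC(CCC(=O)O)C(=O)O)cc2)c2cc(F)c(F)cc2[N+](=O)[O-])c(O)n1` and compound 3 `Nc1nc(N)c(CCCN(Cc2ccc(NC(CCC(=O)O)C(=O)O)cc2)c2ccc([N+](=O)[O-])c(F)c2F)c(O)n1`. All were tested in a functional assay on CCRF-CEM cells (Homo sapiens) for cytotoxicity, in the presence of a further agent that is not named here; a higher number here means a weaker inhibitor, a lower number a stronger inhibitor. In this assay compound 1 gives 43000 nM. For compound 2 the assay reports only a limit, > 100000 nM. For compound 3 it likewise reports only a limit, > 100000 nM.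

Going from compound 2 to compound 1 the change is nitro in place of fluoro on an aromatic carbon, and the step is an at least 2.3-fold lower number from compound 2 to compound 1 (0.36 log units; beyond the scatter). Going from compound 2 to compound 3 the change is 2,3-difluoro-4-nitrophenyl in place of 4,5-difluoro-2-nitrophenyl on an amine nitrogen, and the step is a step that the two limits leave unreadable from compound 2 to compound 3, which rests on (the limit of > 100000 nM in this assay, at which 2 of the 3 values shown sit).

Compound 4 `Nc1nc(N)c(CCCN(Cc2ccc(NC(CCC(=O)O)C(=O)O)cc2)c2ccc([N+](=O)[O-])c(F)c2[N+](=O)[O-])c(O)n1` has not been measured. Its change from compound 3 is nitro in place of fluoro on an aromatic carbon, the same kind of change as from compound 2 to compound 1, though the surroundings are not identical: in compound 4 the new nitro group sits ortho to a large group and meta to a nitro group, whereas in compound 1 it sits meta to a nitro group and para to a large group.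

Since compound 3 sits at a limit, the step to compound 4 can only be bounded from one side. Among the measured compounds shown here, compound 4 is expected to land near compound 1, whose value 43000 nM is the one number on this ring with a nitro group in place of fluoro, giving an estimate of 50000 nM, between 15000 nM and 150000 nM. The step from compound 3 to compound 4 is therefore expected to be an at least 2.0-fold lower number from compound 3 to compound 4 (0.30 log units; that floor lies within the scatter).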

Compound 4, half-maximal inhibitory concentration: 36000 nM
Estimate against measurement, compound 4: 1.4-fold (0.14 log units) above; low and high end bracket the measured number.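

In this assay, nitro in place of fluoro on an aromatic carbon again lowers the number, and the new step is an at least 2.7-fold lower number from compound 3 to compound 4 (0.44 log units; beyond the scatter). The change therefore goes the same way on both cores, and no compound shown goes against this, although two cores are a small sample and the two steps can only be set side by side as minimum sizes: the same change on two cores in this assay, an at least 2.3-fold lower number (0.36 log units; beyond the scatter) from compound 2 to compound 1 and an at least 2.7-fold lower number (0.44 log units; beyond the scatter) from compound 3 to compound 4; the limit leaves it open whether they differ What this does not show is how large either step really is, or whether the change carries over with the same size, because each step starts from a compound reported only as a limit, and the step between those two starting compounds cannot be read either: the limit of > 100000 nM in this assay, at which 2 of the 4 values shown sit.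

The compounds shown leave open whether the lower number is specific to the nitro group or would also appear with another group in the same place, such as a nitrile, a chloro group or an amine. They also leave open how a starting compound with a readable value would respond, since only such a compound could give the change a firm size.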